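This account rests on a few compounds, and the source may have more. Where it says the series, first, only, none or still open, it means among the compounds named here.

Series notes, measured in an ADME assay on NIH3T3 cells (Mus musculus) for cytotoxicity; a lower number here means that less compound is needed, a higher number that more compound is needed for the effect:

- compound 1 `Cc1cc(Oc2cccc(Cn3cncn3)c2)cc(C)c1Cl`: 75900 nM
- compound 2 `Cc1nnc(-c2cccc(Oc3cc(C)c(Cl)c(C)c3)c2)s1`: > 100000 nM

Compound 2 stands at > 100000 nM, which is a limit of this assay and not a number. the limit of > 100000 nM in this assay, at which 1 of the 2 values shown sits, is all that can be said of its position.

Compound 3 `Cc1nnc(Cc2cccc(Oc3cc(C)c(Cl)c(C)c3)c2)s1` carries (5-methyl-1,3,4-thiadiazol-2-yl)methyl in place of 5-methyl-1,3,4-thiadiazol-2-yl on an aromatic carbon.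

Going by the values given here, one measured step bears on this change: an at least 1.3-fold higher number from compound 1 to compound 2 (0.11 log units; that floor lies within the scatter). It is a floor only, and it involves these same two attachment types with a different ring in the methyl-linked group. Among the compounds with values here, compound 1, the one methyl-linked example, gives 75900 nM, so a similarly high value is expected again. The expected outcome is an at least 1.1-fold lower number from compound 2 to compound 3 (0.04 log units; that floor lies within the scatter), which means no step beyond the scatter. For compound 3 the estimated value is 90000 nM, with an expected range of 45000 nM to 180000 nM.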

Compound 3, half-maximal effective concentration: 3800 nM
Compound 3: middle estimate off by 24-fold (1.37 log units), on the high side; the measured number lies below the stated range.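

In this assay, the methyl link on this aromatic carbon, meta to a large group, matters far more than the step from compound 1 to compound 2 suggested: (5-methyl-1,3,4-thiadiazol-2-yl)methyl in place of 5-methyl-1,3,4-thiadiazol-2-yl gives an at least 26-fold lower number from compound 2 to compound 3 (1.42 log units; beyond the scatter). With the methyl link kept, the ring also matters: 5-methyl-1,3,4-thiadiazol-2-yl in place of 1H-1,2,4-triazol-1-yl gives a 20-fold lower number from compound 1 to compound 3 (1.30 log units; beyond the scatter), so among these three compounds the low number appears only where link and thiadiazole occur together, with compound 1 and compound 2 each carrying just one of them. Compound 2 holds a limit of the assay and not a number: the limit of > 100000 nM in this assay, at which 1 of the 3 values shown sits.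

As far as these compounds go, the full size of the first step therefore stays open. Also open, from the compounds shown here alone, is whether a longer chain or an amine as the link would keep the number of compound 3.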